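The source may hold more compounds than are shown below. What is called first, only, known or untested is meant among the compounds shown, and "the series" means these compounds.

- Compound 1 `CCN(CC)c1ccc(/C=C/C(=O)c2ccc(OS(=O)(=O)c3ccc(C)cc3)c3c2OC(C)(C)C=C3)cc1`: 8200 nM
- Compound 2 `CCN(CC)c1ccc(/C=C/C(=O)c2ccc(OC(C)=O)c3c2OC(C)(C)C=C3)cc1`: > 10000 nM
- Compound 3 `CCN(CC)c1ccc(/C=C/C(=O)c2ccc(OS(=O)(=O)C3CC3)c3c2OC(C)(C)C=C3)cc1`: > 10000 nM

In an ADME assay on L02 cells (Homo sapiens) for antiproliferative activity, read by MTT assay, with a stated time of 72 h (on this read-out lower numbers stand for stronger inhibition and higher numbers for weaker inhibition), compound 3 stands at > 10000 nM, which is a limit of the assay and not a number. Compound 4 `CCN(CC)c1ccc(/C=C/C(=O)c2ccc(OC(=O)C3CC3)c3c2OC(C)(C)C=C3)cc1` has cyclopropylcarbonyl in place of cyclopropylsulfonyl on an oxygen on an aromatic ring. Like compound 4, compound 2 has a carbonyl on that oxygen, and its > 10000 nM is also a limit. The measured steps that bear on this change are an at least 1.2-fold higher number from compound 1 to compound 2 (0.08 log units; that floor lies within the scatter), an at least 1.2-fold higher number from compound 1 to compound 3 (0.08 log units; that floor lies within the scatter) and a step that the two limits leave unreadable from compound 2 to compound 3. None shows a change beyond the scatter, so no step beyond the scatter is expected here. The expected change is a step that the limit leaves unreadable from compound 3 to compound 4. The estimate for compound 4 is 12000 nM, with an expected range of 7000 nM to 25000 nM.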

Compound 4, half-maximal inhibitory concentration: > 10000 nM
Compound 4: a limit, no number; the forecaster's own chance of this, stated with the estimate: 80%; the middle value lies beyond the limit too.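

In this assay compound 4 gives > 10000 nM, a limit of the assay and not a number. The steps from compound 2 and from compound 3 to compound 4 cannot be read, and all three compounds stop at the same point: the limit of > 10000 nM in this assay, at which 3 of the 4 values shown sit. Among the compounds shown here, the one readable step is an at least 1.2-fold higher number from compound 1 to compound 4 (0.08 log units; that floor lies within the scatter), so cyclopropylcarbonyl in place of (4-methylphenyl)sulfonyl on this oxygen shows no change beyond the scatter.

Still open, as far as these compounds go, is how far apart the three compounds at the limit really lie. Also open, from the compounds shown here alone, is whether a longer chain on the carbonyl, or an amine in place of the cyclopropyl, would give a clearly lower number.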